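This account rests on a few compounds, and the source may have more. Where it says the series, first, only, none or still open, it means among the compounds named here.

Three thiourea compounds built on one shared core were tested in an ADME assay on MT4 cells (Homo sapiens) for cytotoxicity; on this read-out lower numbers stand for higher toxicity in this test and higher numbers for lower toxicity in this test. Compound 1, `COc1cccc(NC(=S)Nc2cccc(C(F)(F)F)c2)c1`, carries a methoxy group on one of its aromatic rings; in this assay compound 1 gives 26000 nM. Compound 2, `O=C(NC(=S)Nc1cccc(C(F)(F)F)c1)[C@H]1C[C@@H]2CC[C@H]1C2`, replaces that ring with a bicyclic amide and gives 42000 nM, a number that sits within the usual scatter of the reading for compound 1, so no order between the two can be claimed. Compound 3, `O=[N+]([O-])c1ccc(NC(=S)Nc2cccc(C(F)(F)F)c2)cc1`, carries a nitro group instead and gives 9200 nM, a number clearly lower than that of compound 1, beyond the scatter, which marks compound 3 as the more toxic of that pair on this read-out.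

The step under consideration leads from compound 1 to compound 4, `Fc1cccc(NC(=S)Nc2cccc(C(F)(F)F)c2)c1`, which is not yet measured. The change is small: fluoro in place of methoxy on an aromatic carbon. The three measured compounds differ from one another in larger ways, yet their readings span a modest range, and nothing among them points to a fluoro group driving toxicity in either direction. The expectation is therefore that the step from compound 1 to compound 4 in this assay stays within the scatter, with no change of note, as a 1.0-fold lower number from compound 1 to compound 4 (0.02 log units; within the scatter) expresses. Compound 4 is estimated to give 25000 nM, most likely between 10000 nM and 60000 nM.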

Compound 4, half-maximal cytotoxic concentration: 20000 nM
Estimate against measurement, compound 4: 1.3-fold (0.10 log units) above; the range from low to high includes it.
By their numbers in this assay, from the lowest: compound 3; then compounds 4, 1 and 2 (each within the scatter of the next, the first and the last beyond it).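

In this assay, putting fluoro in place of methoxy on an aromatic carbon of the six-membered ring gives a 1.3-fold lower number from compound 1 to compound 4 (0.11 log units; within the scatter), so the test does not tell these two compounds apart. Within the data shown here, this is the first pair that differs in one place only, which makes it the first direct reading of what this position tolerates: methoxy, with two heavy atoms and one hydrogen-bond acceptor, and fluoro, with a single heavy atom and no acceptor, give readings within the scatter of each other. No measurement is available to explain why the two readings stay so close.

As far as these compounds go, the result covers only these two groups, so it remains open whether an amine, a hydroxyl group, a carboxylic acid or a longer chain such as ethoxy at this same carbon would also stay within the scatter of compound 1. From the compounds shown here alone, it also remains open whether fluoro in place of methoxy would give a similar result at another carbon of the ring or on a different core.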